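Acetoxy replacing hydroxyamino at the chain carbon of compound 3

The source may report more compounds than this note shows. Statements on the series, on what has been measured and on what is new or still open speak of the compounds shown alone.

Compound 3 `CCCCC/C=C\C/C=C\C/C=C\C=C\C(CCCC(=O)O)NO` gives 21000 nM in an assay for inhibition of Polyunsaturated fatty acid 5-lipoxygenase (Rattus norvegicus) (on this read-out lower numbers stand for stronger inhibition and higher numbers for weaker inhibition), and stands second highest of the three numbers. Compound 1 `CCCCC/C=C\C/C=C\C/C=C\C=C\C(S)CCCC(=O)O` gives 7600 nM and compound 2 `CCCCC/C=C\C/C=C\C/C=C\C=C\C(CCCC(=O)O)CC(=O)O` gives 96000 nM. Compound 4 `CCCCC/C=C\C/C=C\C/C=C\C=C\C(CCCC(=O)O)OC(C)=O` is not yet measured; it differs from compound 3 by acetoxy in place of hydroxyamino on a saturated chain carbon bound to a double-bonded chain carbon and a saturated chain carbon.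

All three measured steps change the group at this same carbon. The step of a 2.8-fold higher number from compound 1 to compound 3 (0.44 log units; beyond the scatter) is modest, the step of a 4.6-fold lower number from compound 2 to compound 3 (0.66 log units; beyond the scatter) is modest in the other direction, and the step of a 13-fold higher number from compound 1 to compound 2 (1.10 log units; beyond the scatter) is large. For the measured compounds named here, no measured compound carries acetoxy, so the new change has no direct precedent; the existing steps only show that swapping this group shifts the number by a modest to large amount in either direction. A modest upward step a 1.9-fold higher number from compound 3 to compound 4 (0.28 log units; within the scatter) is expected, since the two groups with no hydrogen-bond donor at this carbon gave the two higher numbers. Compound 4 is estimated at 40000 nM, with a range from 12000 nM to 130000 nM.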

Compound 4, half-maximal inhibitory concentration: 68000 nM
For compound 4 the middle estimate is 1.7-fold (0.23 log units) below the measured one, and the stated range covers the measured number.
By their numbers in this assay, from the lowest: compound 1; then compound 3; then compounds 4 and 2 (each within the scatter of the next).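

Acetoxy on this saturated chain carbon falls at the high-number end of the series in this assay, with a 3.2-fold higher number from compound 3 to compound 4 (0.51 log units; beyond the scatter) and, against sulfanyl, an 8.9-fold higher number from compound 1 to compound 4 (0.95 log units; beyond the scatter) as the steps. Against carboxymethyl the step is a 1.4-fold lower number from compound 2 to compound 4 (0.15 log units; within the scatter) and so does not separate these two groups, which leaves sulfanyl in compound 1 and hydroxyamino in compound 3 as the only groups here with clearly lower numbers. No available evidence accounts for this ranking.

On these data alone, whether a hydroxyl or an amine on this carbon would give a number nearer to compound 1 or to compound 4 remains open. As far as these compounds go, it is also open whether a longer acyl chain in place of acetoxy would move the number at all.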